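The source may report more compounds than this note shows. Statements on the series, on what has been measured and on what is new or still open speak of the compounds shown alone.

Working notes on the series. All three measured compounds share one core and differ only in the aryl group on the carbon with a double bond to nitrogen. Compound 1 `Cc1c(C(=O)N/N=C\c2ccccc2F)oc2cccc(O)c12` carries 2-fluorophenyl there; in a functional assay on PC-3 cells (Homo sapiens) for inhibition (on this read-out lower numbers stand for stronger inhibition and higher numbers for weaker inhibition), compound 1 reports only a limit, >= 40000 nM. Compound 2 `Cc1c(C(=O)N/N=C\c2cc(O)ccc2O)oc2cccc(O)c12` carries 2,5-dihydroxyphenyl; in this assay compound 2 gives 95500 nM. Compound 3 `Cc1c(C(=O)N/N=C\c2ccccn2)oc2cccc(O)c12` carries pyridin-2-yl; in this assay compound 3 likewise reports only a limit, >= 40000 nM. Compound 3 thus sits at the unreadable end of the set, and no ordering among the three can be drawn, since (the limit of >= 40000 nM in this assay, at which 2 of the 3 values shown sit). The steps a step that the limit leaves unreadable from compound 1 to compound 2, a step that the two limits leave unreadable from compound 1 to compound 3 and a step that the limit leaves unreadable from compound 2 to compound 3 are all of unreadable size.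

Compound 4 `Cc1c(C(=O)N/N=C\c2ccc(O)cc2O)oc2cccc(O)c12` is not yet measured. Its change from compound 3 is 2,4-dihydroxyphenyl in place of pyridin-2-yl on a carbon with a double bond to nitrogen. The closest measured step, a step that the limit leaves unreadable from compound 2 to compound 3, also exchanges a dihydroxyphenyl against pyridin-2-yl and is unreadable, so no step size can be carried over. The nearest guide is compound 2, which gives 95500 nM in this assay. Compound 4 is therefore expected to remain weak, around 80000 nM with a range of 30000 nM to 300000 nM. The expected step is a step that the limit leaves unreadable from compound 3 to compound 4, with a real chance that only a limit is reported.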

Compound 4, half-maximal inhibitory concentration: 14800 nM
Compound 4: middle estimate off by 5.4-fold (0.73 log units), on the high side; the whole stated range lies above it.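

In this assay, the aryl group on the carbon with a double bond to nitrogen now gives a readable difference: the two dihydroxyphenyl patterns are separated by a 6.5-fold lower number from compound 2 to compound 4 (0.81 log units; beyond the scatter), so the arrangement of the hydroxyl groups on the ring changes the read-out, and not only their presence. Against the two compounds that report only a limit, 2,4-dihydroxyphenyl gives an at least 2.7-fold lower number from compound 3 to compound 4 (0.43 log units; beyond the scatter) and an at least 2.7-fold lower number from compound 1 to compound 4 (0.43 log units; beyond the scatter), and both of these steps are minimum sizes. The steps among compound 1, compound 2 and compound 3 still cannot be read, because of the assay limit: the limit of >= 40000 nM in this assay, at which 2 of the 4 values shown sit.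

On these data alone, it remains open whether the hydroxyl groups of 2,4-dihydroxyphenyl are both needed for the lower number in compound 4. As far as these compounds go, it is also open whether a methoxy group or an amine in their place would keep it.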